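The source may report more compounds than this note shows. Statements on the series, on what has been measured and on what is new or still open speak of the compounds shown alone.

Compound 3 `C=C(c1ccc2c(c1)C=CC(C)(C)O2)c1ccc(OC)cc1NC(=O)CNC` stands highest of the three numbers in a functional assay on A549 cells (Homo sapiens) for antiproliferative activity, read by MTT assay, with a stated time of 48 h; on this read-out higher numbers stand for weaker inhibition and lower numbers for stronger inhibition: compound 3 gives 200 nM, while compound 1 `C=C(c1ccc2c(c1)C=CC(C)(C)O2)c1ccc(OC)cc1NC(=O)CO` gives 40 nM and compound 2 `C=C(c1ccc2c(c1)C=CC(C)(C)O2)c1ccc(OC)cc1NC(=O)CN` gives 60 nM. The step of a 1.5-fold higher number from compound 1 to compound 2 (0.18 log units; within the scatter) lies within the scatter, whereas a 5.0-fold higher number from compound 1 to compound 3 (0.70 log units; beyond the scatter) lies beyond it. Compound 4 `C=C(c1ccc2c(c1)C=CC(C)(C)O2)c1ccc(OC)cc1NC(=O)CNCC` differs from compound 3 by one change: methyl in place of hydrogen on a saturated chain carbon bound to an amine nitrogen. Lengthening the group on the amine nitrogen is expected to raise the number again by a modest amount, roughly a 1.8-fold higher number from compound 3 to compound 4 (0.24 log units; within the scatter), because a 3.3-fold higher number from compound 2 to compound 3 (0.52 log units; beyond the scatter) already showed that adding a methyl there raised the number beyond the scatter. Compound 4 is therefore estimated to give 350 nM in this assay, with a range from 150 nM to 800 nM.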

Compound 4, half-maximal inhibitory concentration: 1180 nM
Compound 4: middle estimate off by 3.4-fold (0.53 log units), on the low side; the measured number lies above the stated range.
By their numbers in this assay, from the lowest: compounds 1 and 2 (each within the scatter of the next); then compound 3; then compound 4.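

The step of a 5.9-fold higher number from compound 3 to compound 4 (0.77 log units; beyond the scatter) shows that the cost at this position did not end with the first methyl: one further carbon on the group on the amine nitrogen weakens inhibition again, beyond the scatter. Among these compounds, measured against the earlier compounds, the ethyl group brings a 20-fold higher number from compound 2 to compound 4 (1.29 log units; beyond the scatter) and the exchange of hydroxy for ethylamino brings a 30-fold higher number from compound 1 to compound 4 (1.47 log units; beyond the scatter) and both steps are large. Across compounds 2, 3 and 4, each added carbon on this nitrogen raises the number, and none of the three goes against this. On these data alone, whether a propyl chain or a second methyl on the same nitrogen would follow stays open. Nothing measured here gives a reason for the rise.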